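Replacing the pyridine ring with a hydroxyphenyl group

A few compounds are considered here, and "the series" means these few. Any claim that something is new, unique, unknown or untested is made for them only; others in the source may bear on it.

Compound 2 `C[C@H](Oc1cccc(F)c1F)C(=O)Nc1ccc2oc(-c3ccncc3)nc2c1` and compound 1 `C[C@H](Oc1cccc(F)c1F)C(=O)Nc1ccc2oc(-c3ccc(F)cc3)nc2c1` share one core and differ only in the ring attached to it. In an assay on isolated protein for inhibition of GMP reductase 2 (Homo sapiens), read by spectrophotometry (on this read-out higher numbers stand for weaker inhibition and lower numbers for stronger inhibition), compound 1 gives > 5000 nM, which is a limit of the assay and not a number. In this assay compound 2 gives > 5000 nM, again a limit. The step from compound 1 to compound 2 is therefore a step that the two limits leave unreadable from compound 1 to compound 2, and the only pattern so far is the limit of > 5000 nM in this assay, at which 2 of the 2 values shown sit.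

Compound 3 `C[C@H](Oc1cccc(F)c1F)C(=O)Nc1ccc2oc(-c3ccc(O)cc3)nc2c1` arises from compound 2 through the change (4-hydroxyphenyl in place of pyridin-4-yl on an aromatic carbon). No measured step reads on this change, since the one step shown, a step that the two limits leave unreadable from compound 1 to compound 2, is unreadable. With compound 2 sitting at > 5000 nM, compound 3 is expected to stay near that limit, so the expected step is a step that the limit leaves unreadable from compound 2 to compound 3, nothing beyond the scatter. The estimate for compound 3 in this assay is 8000 nM, within 2500 nM to 30000 nM.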

Compound 3, inhibition constant: > 5000 nM
Compound 3: no number, only a limit; the forecaster's own chance of this, stated with the estimate: 75%; the middle value is on the limit's open side.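

The steps among compound 1, compound 2 and compound 3 cannot be read, since each value is a limit of the assay and not a number: the limit of > 5000 nM in this assay, at which 3 of the 3 values shown sit. How strongly each of these compounds inhibits, and whether swapping the ring changes anything in this assay, stays open.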